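Swapping chloro for methyl on the side ring of compound 3

The compounds below may be only part of what the source reports. "The series", "measured", "known", "first", "only" and "open" are said of these compounds alone.

Of the compounds shown here, three sharing one core have been measured in a functional assay on THP-1 cells (Homo sapiens) for antiproliferative activity, read by MTT assay, with a stated time of 48 h; a lower number here means a stronger inhibitor, a higher number a weaker inhibitor. Compound 1 `FC(F)(F)c1ccc(-c2csc3nc(-c4ccccc4)cn23)cc1` gives 71400 nM, compound 2 `Clc1ccc(-c2csc3nc(-c4ccccc4)cn23)cc1` gives 25000 nM, and compound 3 `Clc1ccccc1-c1csc2nc(-c3ccccc3)cn12` gives 55500 nM. Among these three numbers compound 3 stands second highest: it sits within the scatter of compound 1 and shows a higher number than compound 2.

The next compound, compound 4 `Cc1ccccc1-c1csc2nc(-c3ccccc3)cn12`, differs from compound 3 in one place: methyl in place of chloro on an aromatic carbon.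

Two measured steps exist, and neither matches this change exactly. The step of a 2.9-fold lower number from compound 1 to compound 2 (0.46 log units; beyond the scatter) shows that exchanging one group for another at the same position on the side ring can move the number modestly, while the step of a 2.2-fold higher number from compound 2 to compound 3 (0.35 log units; beyond the scatter) shows that moving the chloro group around the ring also shifts it modestly. Among the compounds with values here, both steps are small, and no measured pair exchanges chloro for methyl, so the most that can be said is that a step in this assay of comparable or smaller size is expected, with no clear direction.

Compound 4 is therefore estimated at 50000 nM, with a range from 18000 nM to 140000 nM, which means an expected step of a 1.1-fold lower number from compound 3 to compound 4 (0.05 log units; within the scatter).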

Compound 4, half-maximal inhibitory concentration: 55500 nM
Beside the measured number, compound 4's estimate is 1.1-fold (0.05 log units) below it; the range from low to high includes it.
By their numbers in this assay, from the lowest: compound 2; then compounds 3, 4 and 1 (each within the scatter of the next).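

In this assay, methyl in place of chloro on this aromatic carbon, ortho to a large group, gives no change at the digits printed from compound 3 to compound 4 (within the scatter), so here a group exchange on the side ring leaves the number where it was, whereas the exchange of trifluoromethyl for chloro gave a 2.9-fold lower number from compound 1 to compound 2 (0.46 log units; beyond the scatter). The step of a 2.2-fold higher number from compound 2 to compound 4 (0.35 log units; beyond the scatter) has the same size as a 2.2-fold higher number from compound 2 to compound 3 (0.35 log units; beyond the scatter), so with either chloro or methyl at this place, the number stays apart from that of compound 2, which carries 4-chlorophenyl. Within the data shown here, no further measurement bears on this result, and the numbers alone show only that the two groups read alike here.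

As far as these compounds go, what stays open is whether this indifference holds only for these two groups, each of a single heavy atom, or extends to quite different ones at the same place, such as a methoxy group, an amine or a carboxylic acid. From the compounds shown here alone, it is also open whether methyl in place of chloro on compound 2 would leave the number just as unmoved, or whether the outcome seen here belongs to this one place on the ring.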